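This account rests on a few compounds, and the source may have more. Where it says the series, first, only, none or still open, it means among the compounds named here.

Compound 2 `N#CC1=C(N)N(c2ccc(S(N)(=O)=O)cc2)C2=C(C(=O)CCC2)C1c1ccco1` gives 0% in a functional assay on Ehrlich cells (Mus musculus) for antiproliferative activity, read by trypan blue exclusion, with a stated time of 2 h, tested at 10 ug/mL; on this read-out lower numbers stand for a weaker effect and higher numbers for a stronger effect at the one concentration tested; compound 1 `N#CC1=C(N)N(c2ccc(S(N)(=O)=O)cc2)C2=C(C(=O)CCC2)C1/C=C/c1ccccc1` gives 2%, and the step of a number 2 percentage points lower from compound 1 to compound 2 (within the scatter) lies within the scatter, so compound 2 stands alongside compound 1 with no separation beyond the scatter. Compound 3 `N#CC1=C(N)N(c2ccc(S(N)(=O)=O)cc2)C2=C(C(=O)CCC2)C1c1cccs1` differs from compound 2 by thiophen-2-yl in place of furan-2-yl on a saturated ring carbon. For the measured compounds named here, the only measured step, a number 2 percentage points lower from compound 1 to compound 2 (within the scatter), exchanged 2-phenylethenyl for furan-2-yl at this carbon without effect beyond the scatter; no measured step covers furan against thiophene. For compound 3 no step beyond the scatter is expected in this assay, and it is estimated at 1%, range 0% to 10%, an expected step of a number 1 percentage points higher from compound 2 to compound 3 (within the scatter).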

Compound 3, a percentage reported as activity, at one concentration (the size of the read-out at that concentration, not a potency): 70%
Beside the measured number, compound 3's estimate is 69 percentage points below it, outside the stated range (above it).
By their numbers in this assay, from the lowest: compounds 2 and 1 (each within the scatter of the next); then compound 3.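

In this assay the saturated ring carbon proves far from indifferent to its substituent: thiophen-2-yl in place of furan-2-yl gives a number 70 percentage points higher from compound 2 to compound 3 (beyond the scatter) although the two groups match in heavy atoms, ring size and hydrogen-bond counts and differ in sulfur against oxygen. Thiophen-2-yl in place of 2-phenylethenyl gives a number 68 percentage points higher from compound 1 to compound 3 (beyond the scatter) and so shows that the earlier flat step did not mark this carbon as tolerant of any change. Nothing available accounts for the gap between the two five-membered rings.

Open, on these data alone, is whether a plain phenyl or a pyrrol-2-yl ring at this carbon would read like thiophen-2-yl or like furan-2-yl. Also open, as far as these compounds go, is whether the thiophen-2-yl result survives exchanging the sulfonamide for a carboxylic acid.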